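The source may hold more compounds than are shown below. What is called first, only, known or untested is meant among the compounds shown, and "the series" means these compounds.

Measured so far in a toxicity assay on L02 cells (Homo sapiens) for cytotoxicity, read by CCK-8 assay, with a stated time of 72 h; on this read-out higher numbers stand for weaker inhibition and lower numbers for stronger inhibition:
compound 1 `CC(C)(C)OC(=O)/C=C1/C(=O)Nc2ccccc21` gives 2450 nM
compound 2 `CN1C(=O)/C(=C/C(=O)Oc2ccccc2)c2ccccc21` gives 22700 nM
compound 3 `COc1ccc(OC(=O)/C=C2/C(=O)N(C)c3ccccc32)cc1` gives 23500 nM

Compound 1 stands lowest of the three, beyond the scatter from both compound 2 and compound 3. How the core of compound 1 differs from the core of compound 2 is not broken down here. From compound 2 to compound 3 the change is methoxy in place of hydrogen on an aromatic carbon, and it gave a 1.0-fold higher number from compound 2 to compound 3 (0.02 log units; within the scatter).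

Compound 4 `COc1ccc2c(c1)NC(=O)/C2=C/C(=O)OC(C)(C)C` is not yet measured. It derives from compound 1 by methoxy in place of hydrogen on an aromatic carbon. This is the same kind of change as from compound 2 to compound 3 but not the same: there the methoxy enters para to a large group, here it enters on a ring that is part of a fused or bridged system of two rings, meta to a fused ring and para to a fused ring. Because the earlier step was a 1.0-fold higher number from compound 2 to compound 3 (0.02 log units; within the scatter), a step of like size is expected here, a 1.1-fold higher number from compound 1 to compound 4 (0.04 log units; within the scatter). Compound 4 is therefore estimated at 2700 nM in this assay, expected between 1200 nM and 6500 nM.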

Compound 4, half-maximal inhibitory concentration: 4340 nM
Estimate against measurement, compound 4: 1.6-fold (0.21 log units) below, and the stated range covers the measured number.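

In this assay, methoxy in place of hydrogen on an aromatic carbon gives a 1.8-fold higher number from compound 1 to compound 4 (0.25 log units; within the scatter), and set beside the earlier step on the other core it reads: the same change on two cores in this assay, a 1.0-fold higher number (0.02 log units; within the scatter) from compound 2 to compound 3 and a 1.8-fold higher number (0.25 log units; within the scatter) from compound 1 to compound 4, 1.7-fold (0.23 log units) apart, within the scatter of two such steps

On these two pairs, the change carries from one core to the other with no difference that can be told from the scatter, and neither step moves the number beyond the scatter. This does not show that the change would behave alike on other cores, since it rests on two pairs in a single assay, with the methoxy entering a different ring in compound 3 than in compound 4.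

On these data alone, it remains open whether an amine, a carboxylic acid or a longer alkoxy chain at the same place would leave the number as undisturbed as methoxy does. Also open, as far as these compounds go, is how any such group would behave on the core of compound 2.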